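Varying the aryl amide in a P2X7 antagonist series

The source may report more compounds than this note shows. Statements on the series, on what has been measured and on what is new or still open speak of the compounds shown alone.

Three compounds share one core and differ only in the aryl group on the carbonyl carbon. Compound 1 `O=C(c1ccc(Cl)c(C(F)(F)F)c1)N1CCC(n2cncc2-c2ccc(OS(=O)(=O)c3cccc4cnccc34)cc2)CC1` gives 22 nM in an assay on THP-1 cells for antagonist activity at P2X purinoceptor 7 (Homo sapiens), read by ELISA, with a stated time of 30 min (a higher number here means a weaker inhibitor, a lower number a stronger inhibitor), which places it second highest of the three numbers shown. Compound 2 `COc1ccc(C(=O)N2CCC(n3cncc3-c3ccc(OS(=O)(=O)c4cccc5cnccc45)cc3)CC2)cc1` gives 64 nM in this assay, and compound 3 `CS(=O)(=O)c1ccc(C(=O)N2CCC(n3cncc3-c3ccc(OS(=O)(=O)c4cccc5cnccc45)cc3)CC2)cc1` gives 0.32 nM. The step of a 2.9-fold higher number from compound 1 to compound 2 (0.46 log units; beyond the scatter) is modest, whereas a 69-fold lower number from compound 1 to compound 3 (1.84 log units; beyond the scatter) and a 200-fold lower number from compound 2 to compound 3 (2.30 log units; beyond the scatter) are large.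

Compound 4 `CC(C)c1ccc(C(=O)N2CCC(n3cncc3-c3ccc(OS(=O)(=O)c4cccc5cnccc45)cc3)CC2)cc1` carries 4-isopropylphenyl in place of 4-chloro-3-(trifluoromethyl)phenyl on a carbonyl carbon. Both measured steps from compound 1 bear on this change, since each also replaces the same group on the carbonyl carbon, but neither introduces an isopropyl group, so the direction for compound 4 cannot be read directly. The only large gains came with methylsulfonyl, which compound 4 lacks; the methoxy analogue moved modestly upward. The account therefore expects for compound 4 a number close to that of compound 1, with a step of a 1.6-fold higher number from compound 1 to compound 4 (0.20 log units; within the scatter) that may lie within the scatter or be modestly upward. The estimate for compound 4 is 35 nM, within a range from 10 nM to 120 nM.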

Compound 4, half-maximal inhibitory concentration: 37 nM
Compound 4: middle estimate off by 1.1-fold (0.02 log units), on the low side; low and high end bracket the measured number.
By their numbers in this assay, from the lowest: compound 3; then compounds 1, 4 and 2 (each within the scatter of the next, the first and the last beyond it).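

In this assay, 4-isopropylphenyl in place of 4-chloro-3-(trifluoromethyl)phenyl on the carbonyl carbon gives a 1.7-fold higher number from compound 1 to compound 4 (0.23 log units; within the scatter) and isopropyl in place of methoxy gives a 1.7-fold lower number from compound 2 to compound 4 (0.24 log units; within the scatter) even though compound 1 and compound 2 lie beyond the scatter of each other. Against this, a 120-fold higher number from compound 3 to compound 4 (2.06 log units; beyond the scatter) shows that an all-carbon substituent does not reproduce what methylsulfonyl gives, leaving compound 3 alone among the four, well apart from compounds 1, 2 and 4. No evidence is available here to explain why methylsulfonyl stands apart at this place.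

The compounds shown leave open whether the large step belongs to methylsulfonyl alone or would also come with a primary sulfonamide, a nitrile or a carboxylic acid on the same aromatic carbon. They also leave open what an amine or a longer chain carrying the sulfonyl group would give.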